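A few compounds are considered here, and "the series" means these few. Any claim that something is new, unique, unknown or untested is made for them only; others in the source may bear on it.

Compound 1 `O=C(NCc1ccc(S(=O)(=O)c2ccccc2C(F)(F)F)cc1)c1cc2cnccc2[nH]1` at 52%
Compound 2 `O=C(NCc1ccc(S(=O)(=O)c2cccc(C(F)(F)F)c2)cc1)c1ccc2nccn2c1` at 26%

In an ADME assay on microsomes from liver (Homo sapiens) for metabolic stability, read by LC-MS, with a stated time of 30 min, tested at 1 uM (on this read-out higher numbers stand for a more stable compound and lower numbers for a less stable compound), compound 1 holds the higher of the two numbers (52%), and the gap down to compound 2 (26%) lies beyond the scatter. Within the data shown here, no measured pair isolates a single change, so the series offers no direct guide to the next step.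

Compound 3 `O=C(NCc1ccc(S(=O)(=O)c2ccc(F)cc2)cc1)c1cc2cnccc2[nH]1` keeps the core of compound 1 and changes in one place. The change 4-fluorophenyl in place of 2-(trifluoromethyl)phenyl on a sulfonyl sulfur puts 4-fluorophenyl in place of 2-(trifluoromethyl)phenyl on a sulfonyl sulfur. Among the measured compounds shown here, with no measured step for this swap, no step beyond the scatter is expected in this assay and no firm direction can be given. The estimated step is small (a number 4 percentage points lower from compound 1 to compound 3 (within the scatter)). The expected value for compound 3 is 48% (range 28% to 70%).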

Compound 3, percent of the compound remaining: 91%
Compound 3: the middle estimate sits 43 percentage points below what was measured, and the stated range ends below it.
By their numbers in this assay, from the lowest: compound 2; then compound 1; then compound 3.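

Among these compounds, with the core of compound 1 held fixed, 4-fluorophenyl in place of 2-(trifluoromethyl)phenyl on a sulfonyl sulfur gives the first single-change step in this assay, namely a number 39 percentage points higher from compound 1 to compound 3 (beyond the scatter), so the group at this place can by itself move the read-out strongly. Both groups are a six-membered aromatic ring of carbon only, with no hydrogen-bond donors or acceptors and no net charge, so those counted features do not separate them. The swap removes the trifluoromethyl and brings in the fluorine in one step, and the two contributions cannot be told apart here.

Still open, from the compounds shown here alone, is how an unsubstituted phenyl, a 2-fluorophenyl or a pyridine ring on the sulfonyl sulfur would read, and whether the step carries over to the core of compound 2. Nothing at hand bears on the reason for this step.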